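The compounds below may be only part of what the source reports. "The series", "measured", "known", "first", "only" and "open" are said of these compounds alone.

Compound 1 `CC(=O)N1CCc2c(C)c3c(n2-c2ccc(C(N)=O)c(c2)N[C@@H](C)CC1)CC(C)(C)CC3=O` carries an acetyl group on a ring amide nitrogen. Among the compounds with values here, in an in vitro ADME assay on microsomes from liver (Rattus norvegicus) for metabolic stability (a lower number here means that the compound disappears faster, a higher number that the compound lasts longer), compound 1 gives 0.15 h, the only plain number among the three values measured here. Compound 2 `Cc1c2c(n3c1CC(=O)N(CCN(C)C)CC[C@H](C)Nc1cc-3ccc1C(N)=O)CC(C)(C)CC2=O` reaches in this assay only a limit of the assay, > 0.5 h, not a number. Compound 3 `COCCN1CC[C@H](C)Nc2cc(ccc2C(N)=O)-n2c(c(C)c3c2CC(C)(C)CC3=O)CC1=O` likewise sits in this assay at the limit > 0.5 h. The step that the two limits leave unreadable from compound 2 to compound 3 stays unreadable because the limit of > 0.5 h in this assay, at which 2 of the 3 values shown sit, is where both compounds sit. Compound 4 `Cc1c2c(n3c1CCN(C(=O)[C@H](C)N)CC[C@H](C)Nc1cc-3ccc1C(N)=O)CC(C)(C)CC2=O` differs from compound 1 by 1-aminoethyl in place of methyl on a carbonyl carbon. Within the data shown here, no measured step changes a carbonyl carbon in this way, so no step beyond the scatter is expected in either direction. Compound 4 is therefore estimated at 0.2 h, between 0.08 h and 0.5 h, an expected step of a 1.3-fold higher number from compound 1 to compound 4 (0.12 log units; within the scatter).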

Compound 4, half-life: > 0.5 h
Compound 4: a limit, no number; the forecaster's own chance of this, stated with the estimate: 25%; middle value at least 2.5-fold (0.39 log units) away from the limit.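

Replacing methyl with 1-aminoethyl on a carbonyl carbon gives the first change of readable size among these compounds: an at least 3.3-fold higher number from compound 1 to compound 4 (0.52 log units; beyond the scatter). This change at this position therefore makes the compound last longer in this assay, beyond the usual scatter. In that assay compound 4 gives > 0.5 h, a limit of the assay and not a number.

How large the step really is stays open because of where compound 4 sits: the limit of > 0.5 h in this assay, at which 3 of the 4 values shown sit. The compounds shown also cannot tell whether an ethyl group, without the amine, or a carboxylic acid on this carbonyl carbon would do the same.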